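Five-membered aryl variants at the fused core, toward a pyridine

This account rests on a few compounds, and the source may have more. Where it says the series, first, only, none or still open, it means among the compounds named here.

Compound 1 `COC(=O)c1sc2cc(-c3ccsc3)cnc2c1N` gives 12100 nM in a functional assay on A-375 cells (Homo sapiens) for inhibition, read by sulforhodamine B assay, with a stated time of 48 h; a higher number here means a weaker inhibitor of growth, a lower number a stronger inhibitor of growth. Compound 2 `COC(=O)c1sc2cc(-c3cccs3)cnc2c1N` reaches only the limit of the assay, > 150000 nM. Compound 3 `COC(=O)c1sc2cc(-c3cnn(C)c3)cnc2c1N` likewise sits at the limit, > 150000 nM. The measured steps are an at least 12-fold higher number from compound 1 to compound 2 (1.09 log units; beyond the scatter) and an at least 12-fold higher number from compound 1 to compound 3 (1.09 log units; beyond the scatter); the step between compound 2 and compound 3 is a step that the two limits leave unreadable from compound 2 to compound 3, since both rest on (the limit of > 150000 nM in this assay, at which 2 of the 3 values shown sit). Compound 3 therefore stands at the weak end of what has been measured, with no number of its own.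

Compound 4 `COC(=O)c1sc2cc(-c3cccnc3)cnc2c1N` differs from compound 3 by pyridin-3-yl in place of 1-methyl-1H-pyrazol-4-yl on an aromatic carbon. Among the compounds with values here, no measured step involves a six-membered aryl group, and no step starts from the pyrazole with a readable size, so a direct comparison is lacking. Both changes away from the thiophen-3-yl of compound 1 gave large losses, and the pyridin-3-yl is closer in shape to neither. The expected step of an at least 1.8-fold lower number from compound 3 to compound 4 (0.27 log units; that floor lies within the scatter) in this assay is a modest recovery at most, with a strong chance that only the limit is returned. The estimate for compound 4 is 80000 nM, between 12000 nM and 400000 nM.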

Compound 4, concentration for 50% growth inhibition: > 112000 nM
Compound 4: only a limit was reported; the forecaster's own chance of this, stated with the estimate: 50%; middle value at least 1.4-fold (0.14 log units) from the limit.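

In this assay, compound 4 gives a limit and not a number: the limit of > 112000 nM in this assay, at which 1 of the 4 values shown sits.

The change from thiophen-3-yl to pyridin-3-yl gives an at least 9.2-fold higher number from compound 1 to compound 4 (0.96 log units; beyond the scatter), so at this position the loss is not confined to five-membered replacements and extends to a six-membered aromatic ring. Among the compounds shown, only compound 1 gives a readable value, 12100 nM, and the steps among compound 2, compound 3 and compound 4 cannot be read.

Open, going by these compounds, is whether a plain phenyl ring or a furan-3-yl group on this aromatic carbon would give a readable value in this assay. Also open, on these data alone, is how far compound 2, compound 3 and compound 4 lie beyond their limits, and so whether the hetero atoms of these rings order them at all.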